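The source may report more compounds than this note shows. Statements on the series, on what has been measured and on what is new or still open speak of the compounds shown alone.

Working notes on the series. Compound 1 `Cc1nn(C)c2c1C(c1ccccc1)C(C#N)=C(N)O2` gives 9100 nM in a functional assay on NCI-H2122 cells (Homo sapiens) for inhibition, read by microscopy, with a stated time of 10 days; a lower number here means a stronger inhibitor, a higher number a weaker inhibitor. Compound 2 `Cn1nc(-c2ccccc2)c2c1OC(N)=C(C#N)C2c1ccccc1` reaches only a limit of this assay, > 10000 nM. Compound 3 `COc1ccc(C2C(C#N)=C(N)Oc3c2c(C)nn3C)cc1F` gives 5800 nM in this assay; how its core differs from that of compound 1 is not broken down here. Compound 4 `COc1ccc(C2C(C#N)=C(N)Oc3c2c(-c2ccccc2)nn3C)cc1F` has not yet been measured in this assay.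

The step from compound 1 to compound 2 is phenyl in place of methyl on an aromatic carbon, and it gave an at least 1.0-fold higher number from compound 1 to compound 2 (0.04 log units; that floor lies within the scatter), a floor set by the limit of > 10000 nM in this assay, at which 1 of the 3 values shown sits. The change from compound 3 to compound 4 is phenyl in place of methyl on an aromatic carbon, the same change at the same place. Compound 4 is therefore expected to give a number no lower than compound 3, the step of a 1.6-fold higher number from compound 3 to compound 4 (0.19 log units; within the scatter) resting on the measured pair and carrying the chance of another limit. For compound 4 the estimate is 9000 nM, between 4000 nM and 20000 nM.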

Compound 4, half-maximal inhibitory concentration: > 10000 nM
Compound 4 ended at the assay's limit (the forecaster's own chance of this, stated with the estimate: 40%); middle value at least 1.1-fold (0.04 log units) from the limit.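

In this assay, phenyl in place of methyl on an aromatic carbon gave an at least 1.7-fold higher number from compound 3 to compound 4 (0.23 log units; that floor lies within the scatter), and compound 4 ends at a limit of the assay, as compound 2 does: the limit of > 10000 nM in this assay, at which 2 of the 4 values shown sit. Set side by side, the change gives no lower number on either core, but this does not show that it carries over with the same size: the same change on two cores in this assay, an at least 1.0-fold higher number (0.04 log units; that floor lies within the scatter) from compound 1 to compound 2 and an at least 1.7-fold higher number (0.23 log units; that floor lies within the scatter) from compound 3 to compound 4; the limit leaves it open whether they differ. The step between compound 2 and compound 4 cannot be read.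

The compounds shown leave open whether an amine, a carboxylic acid or a longer chain in place of methyl on this aromatic carbon would give a number clear of the limit. They also leave open how the change behaves with anything other than phenyl or 3-fluoro-4-methoxyphenyl on the saturated ring carbon.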